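The source may report more compounds than this note shows. Statements on the series, on what has been measured and on what is new or still open speak of the compounds shown alone.

Measured so far:
- compound 1, `Cc1ccccc1-n1cc(CNC(=O)[C@@H](N)CCSC[C@H]2O[C@@H](n3cnc4c(N)ncnc43)[C@H](O)[C@@H]2O)cn1`: 28000 nM
- compound 2, `Nc1ncnc2c1ncn2[C@@H]1O[C@H](CSCC[C@H](N)C(=O)NCc2cc3n(n2)CCN(Cc2ccccc2)C3)[C@@H](O)[C@H]1O`: 8000 nM

Both compounds were tested in an assay on Sf9 cells for inhibition of histone-lysine N-methyltransferase EZH2 (Homo sapiens), read by scintillation counting, in the presence of a further agent that is not named here; on this read-out higher numbers stand for weaker inhibition and lower numbers for stronger inhibition. On this read-out compound 1 has the higher of the two numbers, so it is the weaker inhibitor of the pair; compound 2 comes in with a number that sits a clear step lower, and that gap is wider than what repeated measurements of this kind would usually produce.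

The next compound, compound 3, `Nc1ncnc2c1ncn2[C@@H]1O[C@H](CSCC[C@H](N)C(=O)NCc2cc(C3CCC3)[nH]n2)[C@@H](O)[C@H]1O`, keeps the shared core of compound 1 and changes only the group that hangs on the amide. The change is a group of 9 heavy atoms (7 carbon, 2 nitrogen; one four-membered non-aromatic ring of carbon only, one five-membered aromatic ring with 2 hetero atoms) in place of a group of 12 heavy atoms (10 carbon, 2 nitrogen; one five-membered aromatic ring with 2 hetero atoms, one six-membered aromatic ring of carbon only), on a saturated chain carbon bound to an amide-type nitrogen. In plain terms, the aryl-substituted five-membered ring of compound 1 gives way to a smaller five-membered ring carrying a four-membered carbocycle, and the new ring now carries a hydrogen on a ring nitrogen.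

For the measured compounds named here, no pair of measured compounds differs in just one place, so there is no measured step to lean on. The move to a smaller, less aromatic substituent is expected to shift the number modestly downward, within or close to the usual scatter, giving an expected step of a 1.9-fold lower number from compound 1 to compound 3 (0.27 log units; within the scatter). For compound 3 the estimated value in this assay is 15000 nM, with a range from 4000 nM to 60000 nM.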

Compound 3, half-maximal inhibitory concentration: 3000 nM
Estimate against measurement, compound 3: 5.0-fold (0.70 log units) above, and the stated range ends above it.
By their numbers in this assay, from the lowest: compound 3; then compound 2; then compound 1.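

In this assay, the group on the saturated chain carbon bound to an amide-type nitrogen clearly matters, with a 9.3-fold lower number from compound 1 to compound 3 (0.97 log units; beyond the scatter), a step beyond the usual scatter and the first single-place comparison available here. The six-membered aromatic ring of carbon only in the leaving group is therefore not required for inhibition at this level, since the entering group of 9 heavy atoms, with its four-membered non-aromatic ring of carbon only, gives the lower number and also has 1 hydrogen-bond donor where the leaving group has 0. Nothing measured here shows which of these differences accounts for the step.

This single change alters the ring substituent and the hydrogen on the ring nitrogen together, so their separate contributions remain unresolved. A cyclopropyl, cyclopentyl or methyl group in place of the four-membered ring would show how the number follows the size of that substituent, while a methyl group in place of the hydrogen on the ring nitrogen would test that hydrogen alone.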